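A few compounds are considered here, and "the series" means these few. Any claim that something is new, unique, unknown or untested is made for them only; others in the source may bear on it.

Of the compounds shown here, two have so far been tested in an assay on HEK293 cells for binding affinity to 5-hydroxytryptamine receptor 7 (Homo sapiens), read by radioligand binding, tested at 1 uM; on this read-out higher numbers stand for more inhibition at the one concentration tested (going by the name of the read-out) and lower numbers for less inhibition. Compound 1, `Brc1ccc2ccn(CCN3CCC4CCCCN4CC3)c2c1`, gives 71%. Compound 2, `CC(C)N1CCCN(CCn2ccc3ccc(Br)cc32)CC1`, gives 92%, the higher of the two numbers, and its gap to compound 1 lies beyond the scatter of repeated measurements. Compound 3, `Brc1ccc2ccn(CCN3CCCN(C4CCCCC4)CC3)c2c1`, has not yet been measured. It differs from compound 2 in one place: cyclohexyl in place of isopropyl on an amine nitrogen in a ring. Among the compounds with values here, no step between two measured compounds shows what a change of this kind does here, so the expectation rests on compound 2 alone. Because compound 2 already gives 92%, a number near the top of the scale, only a small step is expected, a number 4 percentage points lower from compound 2 to compound 3 (within the scatter), one that stays within the scatter in either direction. Compound 3 is therefore expected to give 88% in this assay, with a likely range from 70% to 98%.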

Compound 3, a percentage reported as inhibition, at one concentration (the size of the read-out at that concentration, not a potency): 96%
Beside the measured number, compound 3's estimate is 8 percentage points below it, within the range that was stated.
By their numbers in this assay, from the lowest: compound 1; then compounds 2 and 3 (each within the scatter of the next).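

Cyclohexyl in place of isopropyl on this amine nitrogen gives a number 4 percentage points higher from compound 2 to compound 3 (within the scatter) in this assay, so the first direct comparison at this position shows no change beyond the scatter. A group of 6 heavy atoms carrying its own six-membered ring can stand here, where isopropyl had 3 heavy atoms and no ring, and the number stays near the top of the scale. Nothing available here gives a reason for this result.

On these data alone, whether the high numbers hold with a hydrogen, a methyl or a benzyl group on this nitrogen remains open, as does the effect of an amide at this position. A read-out at one concentration, so close to the top of the scale, also leaves open how compound 2 and compound 3 would compare in potency.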